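The source may report more compounds than this note shows. Statements on the series, on what has been measured and on what is new or still open speak of the compounds shown alone.

Compound 1 `O=C(C1CC1)[C@H]1C[C@H]2CNC[C@H]2C1` and compound 2 `O=C(c1ccco1)[C@H]1C[C@H]2CNC[C@H]2C1` are the two measured compounds. In an assay on CHO cells for agonist activity at Neuronal acetylcholine receptor; alpha3/beta4 (Homo sapiens), read by FLIPR and calcium flux (a higher number here means a larger maximal response, a lower number a smaller maximal response), compound 1 gives 130%, and compound 2 gives 40%.

Compound 2 therefore stands at the lowest of the two numbers; its nearest neighbour is compound 1, and the step between them, a number 90 percentage points lower from compound 1 to compound 2 (beyond the scatter), is large and beyond the scatter. Going by the values given here, that step changed the group on the carbonyl carbon, and it is the only measured step available.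

Compound 3 `COC(=O)[C@H]1C[C@H]2CNC[C@H]2C1` is not yet measured. It differs from compound 2 in one place: methoxy in place of furan-2-yl on a carbonyl carbon. The same carbonyl carbon is altered as in the step from compound 1 to compound 2, so that step is the one that bears on the prediction. It shows that exchanging the group on this carbon can move the maximal response by a large amount. Among the compounds with values here, no measured pair compares methoxy with furan-2-yl, so the direction for compound 3 is uncertain, though the large size of a number 90 percentage points lower from compound 1 to compound 2 (beyond the scatter) suggests a substantial shift is possible.

Compound 3 is expected to give 75%, within 30% to 125%. The expected step is a number 35 percentage points higher from compound 2 to compound 3 (beyond the scatter).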

Compound 3, largest response reached (Emax), in percent of the reference or control that the assay uses: 100%
Compound 3: the middle estimate sits 25 percentage points below what was measured, and the stated range covers the measured number.
By their numbers in this assay, from the lowest: compound 2; then compound 3; then compound 1.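

Replacing furan-2-yl with methoxy on this carbonyl carbon in this assay gives a large recovery of the response (a number 60 percentage points higher from compound 2 to compound 3 (beyond the scatter)), yet the recovery stops short of the cyclopropyl compound (a number 30 percentage points lower from compound 1 to compound 3 (beyond the scatter)), a modest step. With three groups now compared at one place, the response no longer looks like a simple contrast between a high and a low group, since methoxy falls in the middle and the low number seen with furan-2-yl is not shared by a group that has no ring. The order also does not follow the presence of a ring, as the two groups with rings, cyclopropyl and furan-2-yl, stand at opposite ends and methoxy, without one, lies between them, and no available evidence accounts for this order.

The compounds shown leave open where an amine on the same carbonyl carbon, or a longer chain in place of methoxy, would fall in this order. They also leave open whether any other group at this place, such as a carboxylic acid or a larger saturated ring, would match or pass cyclopropyl.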